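A few compounds are considered here, and "the series" means these few. Any claim that something is new, unique, unknown or untested is made for them only; others in the source may bear on it.

Of the compounds shown here, two with a shared core have been measured so far. Compound 1 `O=C(Nc1ccc2nc(NC(=O)C3CCCCC3)sc2c1)c1ccccc1F` and compound 2 `CCCCCCCC(=O)Nc1nc2ccc(NC(=O)c3c(Cl)cccc3Cl)cc2s1` differ at both ends of that core. In a functional assay on WI-38 VA13 cells (Homo sapiens) for cytotoxicity (a higher number here means that more compound is needed for the effect, a lower number that less compound is needed), compound 1 gives 0.14 ug/mL, and in this assay compound 2 gives 0.18 ug/mL. Compound 2 thus gives the higher of the two numbers, but the gap to compound 1 lies within the usual scatter of such measurements, so the two cannot be told apart.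

Compound 3 `O=C(Nc1ccc2nc(NCC3CCCCC3)sc2c1)c1c(Cl)cccc1Cl` has not yet been measured. It differs from compound 2 in one place: cyclohexylmethyl in place of heptylcarbonyl on a nitrogen on an aromatic ring. Going by the values given here, no measured pair shows this change, so nothing in the data says how large a step it produces. Among the compounds with values here, both measured compounds carry an acyl group on that nitrogen, and compound 3 is the first without one.

The step from compound 2 to compound 3 is expected to be modest and to run toward a higher number, with an estimated size of a 2.2-fold higher number from compound 2 to compound 3 (0.35 log units; beyond the scatter). For compound 3 the expected value in this assay is 0.4 ug/mL, with a range from 0.08 ug/mL to 2 ug/mL.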

Compound 3, half-maximal effective concentration: 4.3 ug/mL
Beside the measured number, compound 3's estimate is 11-fold (1.03 log units) below it; the measured number lies above the stated range.
By their numbers in this assay, from the lowest: compounds 1 and 2 (each within the scatter of the next); then compound 3.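

In this assay, the nitrogen on an aromatic ring proves sensitive to the group it carries: cyclohexylmethyl in place of heptylcarbonyl gives a 24-fold higher number from compound 2 to compound 3 (1.38 log units; beyond the scatter). Both earlier compounds carry an acyl group on this nitrogen, so they could not show what happens without one; compound 3 shows that such a replacement can cost a large shift toward needing more compound for the cytotoxic effect. Nothing available explains the size of this step.

The step also joins two changes, since the carbonyl leaves and a six-membered ring of carbon enters in place of an open chain, so it remains open which of them accounts for the shift. With the rest of compound 3 kept, an octyl chain on this nitrogen would test the loss of the carbonyl without the ring, while cyclohexylcarbonyl would test the ring with the carbonyl retained.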